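Ring in place of chain on the shared core: compound 4

The source may hold more compounds than are shown below. What is called first, only, known or untested is meant among the compounds shown, and "the series" means these compounds.

Compound 3 `CC(C)CCOc1cc(C(C)(C)C)ccc1CNC(=O)C(C)c1ccc(NS(C)(=O)=O)c(F)c1` gives 0.6 nM in an assay on cells for antagonist activity at transient receptor potential cation channel subfamily V member 1 (Homo sapiens), read by FLIPR and calcium flux, with a stated time of 6 min (a lower number here means a stronger inhibitor, a higher number a weaker inhibitor), the lowest number of the three measured. Compound 2 `CCCCOc1cc(C(C)(C)C)ccc1CNC(=O)C(C)c1ccc(NS(C)(=O)=O)c(F)c1` gives 1.4 nM, and compound 1 `CC(C(=O)NCc1ccc(C(C)(C)C)cc1N1CCCC1)c1ccc(NS(C)(=O)=O)c(F)c1` gives 8.1 nM. The measured steps are a 5.8-fold lower number from compound 1 to compound 2 (0.76 log units; beyond the scatter), a 14-fold lower number from compound 1 to compound 3 (1.13 log units; beyond the scatter) and a 2.3-fold lower number from compound 2 to compound 3 (0.37 log units; beyond the scatter). Compound 4 `CC(C(=O)NCc1ccc(C(C)(C)C)cc1C1CCCCC1)c1ccc(NS(C)(=O)=O)c(F)c1` carries the change (cyclohexyl in place of isopentyloxy on an aromatic carbon). Among the compounds with values here, no measured step covers cyclohexyl on the aromatic carbon; the nearest comparison is the large step of a 14-fold lower number from compound 1 to compound 3 (1.13 log units; beyond the scatter), in which a ring group gave way to a chain. A ring group returning on that carbon is therefore expected to give a number higher than that of compound 3 but short of that of compound 1. Compound 4 is expected at 3 nM, within 0.8 nM to 12 nM, a step of a 5.0-fold higher number from compound 3 to compound 4 (0.70 log units; beyond the scatter).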

Compound 4, inhibition constant: 9.8 nM
Compound 4: middle estimate off by 3.3-fold (0.51 log units), on the low side; low and high end bracket the measured number.
By their numbers in this assay, from the lowest: compound 3; then compound 2; then compounds 1 and 4 (each within the scatter of the next).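

On this aromatic carbon, cyclohexyl gives up the gain seen with the chains in this assay (a 16-fold higher number from compound 3 to compound 4 (1.21 log units; beyond the scatter); a 7.0-fold higher number from compound 2 to compound 4 (0.85 log units; beyond the scatter)). It reads the same as pyrrolidin-1-yl within the scatter (a 1.2-fold higher number from compound 1 to compound 4 (0.08 log units; within the scatter)), so among the compounds shown, both ring groups sit above both oxygen-linked chains, with no exception. Nothing measured here explains this split between rings and chains.

The compounds shown leave open whether the ring itself or the missing ether oxygen accounts for the difference. Cyclohexyloxy, carrying both the ring and that oxygen, would separate the two.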